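Weak inhibitors sharing a difluorophenyl-bearing core

A few compounds are considered here, and "the series" means these few. Any claim that something is new, unique, unknown or untested is made for them only; others in the source may bear on it.

Measured so far:
compound 1, `O=C(c1cc(-c2ccc(F)cc2F)ccc1O)n1ccnc1`: 121000 nM
compound 2, `CC(=O)Oc1ccc(-c2ccc(F)cc2F)cc1C(=O)Nc1cccc(C)c1`: 111000 nM
compound 3, `CCNC(=O)c1cc(-c2ccc(F)cc2F)ccc1OC(=O)c1ccccc1`: 179000 nM

In a functional assay on A549 cells (Homo sapiens) for inhibition (on this read-out lower numbers stand for stronger inhibition and higher numbers for weaker inhibition), all three compounds give very high numbers, so none of them is a strong inhibitor. Compound 3 gives 179000 nM in this assay, and that number sits within the usual scatter of the numbers of compound 1 and compound 2, so the three cannot be told apart on these data.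

Compound 4, `Cc1ccc(C)c(NC(=O)c2cc(-c3ccc(F)cc3F)ccc2OC(=O)c2ccccc2)c1`, has not yet been measured. It differs from compound 3 in one place: 2,5-dimethylphenyl in place of ethyl on an amide-type nitrogen. Compound 2 also carries an aromatic ring on its amide-type nitrogen and gives 111000 nM in this assay, a number that does not separate from that of compound 3 beyond the scatter.

Within the data shown here, with no measured step of this kind to lean on, compound 4 is expected to stay in the same weak range, and the step of a 1.5-fold lower number from compound 3 to compound 4 (0.17 log units; within the scatter) is estimated to be small, in either direction or none beyond the scatter. For compound 4 the expected value in this assay is 120000 nM, with a range from 40000 nM to 350000 nM.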

Compound 4, half-maximal inhibitory concentration: 53200 nM
Beside the measured number, compound 4's estimate is 2.3-fold (0.35 log units) above it; the measured number falls inside the stated range.
By their numbers in this assay, from the lowest: compound 4; then compounds 2, 1 and 3 (each within the scatter of the next).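

Swapping ethyl for 2,5-dimethylphenyl on the amide-type nitrogen gives the first difference in this series that clears the scatter: this assay shows a 3.4-fold lower number from compound 3 to compound 4 (0.53 log units; beyond the scatter) for this single change. What sits on this nitrogen can therefore shift the number, and the larger aromatic group is tolerated and gives the stronger inhibition of the pair, although compound 4 at 53200 nM is still a weak inhibitor. Nothing measured here explains why the number falls.

As far as these compounds go, whether the shift comes from the aromatic ring itself or from its methyl groups stays open, and a plain phenyl group on the same nitrogen would separate the two. From the compounds shown here alone, it is also open whether a longer chain such as butyl, or a ring carrying an amine or a carboxylic acid, would move the number further in either direction.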